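Notes on the amide nitrogen substituent in the ester series

A few compounds are considered here, and "the series" means these few. Any claim that something is new, unique, unknown or untested is made for them only; others in the source may bear on it.

Compound 2 `CC(=O)Oc1ccc(-c2ccc(F)cc2F)cc1C(=O)Nc1ccccc1C` stands lowest of the two numbers in a functional assay on the whole organism (Ear) for inhibition, with Mus musculus as the target, at a dose of 40 mg/kg by the oral route (a lower number here means less inhibition, a higher number more inhibition at the dose given (going by the name of the read-out)), where compound 2 gives 19.6%. Its nearest neighbour is compound 1 `CNC(=O)c1cc(-c2ccc(F)cc2F)ccc1OC(C)=O`, which in this assay gives 48.8%. Among the measured compounds shown here, the single measured step, a number 29.2 percentage points lower from compound 1 to compound 2 (beyond the scatter), comes from putting 2-methylphenyl in place of methyl on an amide-type nitrogen.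

Compound 3 `CC(=O)Oc1ccc(-c2ccc(F)cc2F)cc1C(=O)Nc1cc(C)ccc1C` differs from compound 2 by methyl in place of hydrogen on an aromatic carbon, read one bond further out as 2-methylphenyl to 2,5-dimethylphenyl. For the measured compounds named here, no measured step alters a substituent on that aryl ring; the only step known replaces the whole nitrogen substituent, so it bears on compound 3 only indirectly. Nothing in the numbers points to a shift beyond the scatter in this assay for compound 3, and the step is expected to be a number 1.6 percentage points lower from compound 2 to compound 3 (within the scatter). Compound 3 is therefore estimated at 18%, within 4% to 35%.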

Compound 3, a percentage reported as inhibition, in the whole organism at one dose (the size of the read-out at that dose, not a potency): 22%
For compound 3 the middle estimate is 4 percentage points below the measured one; the measured number falls inside the stated range.
By their numbers in this assay, from the lowest: compounds 2 and 3 (each within the scatter of the next); then compound 1.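

In this assay (this assay), the change on the 2-methylphenyl ring itself does not separate the two compounds: methyl in place of hydrogen, para to a methyl group, gives a step within the scatter (a number 2.4 percentage points higher from compound 2 to compound 3 (within the scatter)). The 2,5-dimethylphenyl group on the amide nitrogen also stays well short of methyl there (a number 26.8 percentage points lower from compound 1 to compound 3 (beyond the scatter)), so this is a second aryl substituent with a step beyond the scatter in the same direction as the 2-methylphenyl step. No measurement at hand bears on why the nitrogen substituent matters while the added ring methyl does not.

Still open, on these data alone, is whether a carboxylic acid or an amine on this ring would move the read-out, as only methyl has been seen there. A longer alkyl chain, such as butyl, on the amide nitrogen would show whether the loss seen here belongs to aryl groups or extends beyond them.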